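A few compounds are considered here, and "the series" means these few. Any claim that something is new, unique, unknown or untested is made for them only; others in the source may bear on it.

Measured so far:
Compound 1, `Cc1ccccc1Oc1ccc(N2CCC[C@H]2CC(=O)O)cc1`: 5600 nM
Compound 2, `COc1ccc(Oc2ccc(N3CCC[C@H]3CC(=O)O)cc2)cc1`: > 33000 nM

Two compounds share a core carrying an acid on a ring nitrogen, and differ only in the ring that hangs on the ether oxygen. In a functional assay on cells for agonist activity at Free fatty acid receptor 1 (Mus musculus), read by FLIPR and calcium flux, with a stated time of 100 s (a higher number here means that more compound is needed for the effect, a lower number that less compound is needed), compound 1 gives 5600 nM. Going by the values given here, this is the only number in the set. Compound 2 reaches only a limit of the assay, > 33000 nM. Among the compounds with values here, the one step between measured compounds, an at least 5.8-fold higher number from compound 1 to compound 2 (0.77 log units; beyond the scatter), is known only as a lower bound because compound 2 sits at the limit of > 33000 nM in this assay, at which 1 of the 2 values shown sits.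

Compound 3, `COc1ccc(F)c(-c2cccc(Oc3ccc(N4CCC[C@H]4CC(=O)O)cc3)c2C)c1`, changes a different place than that step: 2-fluoro-5-methoxyphenyl in place of hydrogen on an aromatic carbon. Within the data shown here, no measured step covers an addition at this position, so the measured step from compound 1 to compound 2 does not bear on it, and the estimate can rest only on the value of compound 1. Compound 3 is expected to give 400 nM, with a range from 60 nM to 3000 nM. The expected step is a 14-fold lower number from compound 1 to compound 3 (1.15 log units; beyond the scatter).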

Compound 3, half-maximal effective concentration: 3000 nM
Compound 3: the middle estimate sits 7.5-fold (0.88 log units) below what was measured; the range from low to high includes it.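

In this assay, placing 2-fluoro-5-methoxyphenyl on this aromatic carbon, ortho to a methyl group, gives a 1.9-fold lower number from compound 1 to compound 3 (0.27 log units; within the scatter) and so the two compounds cannot be told apart. The earlier compounds shown here swapped the whole ring on the ether oxygen, whereas here that ring of compound 1 stays in place and carries one more six-membered aromatic ring, and the reading stays within the ordinary spread of repeat measurements. Going by these compounds alone, this position therefore takes a substituent of this size without a change that the assay can resolve, and nothing measured so far accounts for that result.

As far as these compounds go, whether a much smaller group at this position, such as a single chlorine atom, or an added ring bearing an amine or a carboxylic acid, would shift the number remains open. Also open, from the compounds shown here alone, is what the fluorine and the methoxy group on the added ring each contribute on their own, and whether either one matters at all to the reading at this receptor.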